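Hydroxy in place of methoxy: cytotoxicity in a urea series

The source may hold more compounds than are shown below. What is called first, only, known or untested is meant among the compounds shown, and "the series" means these compounds.

compound 1 `COc1ccc(NC(=O)Nc2cc(C)nc3ccccc23)cc1` — > 25000 nM
compound 2 `Cc1cc(NC(=O)Nc2ccc(C(=O)O)cc2)c2ccccc2n1` — > 25000 nM
compound 3 `Cc1cc(NC(=O)Nc2ccccc2F)c2ccccc2n1` — > 25000 nM

In an ADME assay on HEK293 cells (Homo sapiens) for cytotoxicity, with a stated time of 72 h (a lower number here means that less compound is needed, a higher number that more compound is needed for the effect), compound 1 reaches only a limit of the assay, > 25000 nM. Compound 2 likewise stops at a limit, > 25000 nM. Compound 3 also stops at a limit, > 25000 nM. Among the measured compounds shown here, the single measured step between compounds that differ in one place, a step that the two limits leave unreadable from compound 1 to compound 2, is one that the two limits leave unreadable, so it gives no size to carry over. The whole of the measured picture is summed up by the limit of > 25000 nM in this assay, at which 3 of the 3 values shown sit.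

Compound 4 `Cc1cc(NC(=O)Nc2ccc(O)cc2)c2ccccc2n1` differs from compound 1 by hydrogen in place of methyl on an oxygen on an aromatic ring. For the measured compounds named here, no measured step bears directly on this change, and none of the three values shown is a number rather than a limit. On that basis compound 4 is expected to behave like its three measured neighbours, and the step that the limit leaves unreadable from compound 1 to compound 4 is estimated to be none beyond the scatter. The estimate for compound 4 in this assay is 30000 nM, with a range from 10000 nM to 100000 nM.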

Compound 4, half-maximal effective concentration: > 25000 nM
Compound 4: a limit, no number (the forecaster's own chance of this, stated with the estimate: 80%); the middle value is on the limit's open side.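

Among the compounds shown here, compound 4 gives > 25000 nM and that is a limit, so no step linking it with compound 1, compound 2 or compound 3 can be read. What the compounds shown leave open is which change on the shared core, if any, would give a number rather than a limit: the limit of > 25000 nM in this assay, at which 4 of the 4 values shown sit.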